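Two Chlorines in Place of One Fluorine on the Thioether

The source may report more compounds than this note shows. Statements on the series, on what has been measured and on what is new or still open speak of the compounds shown alone.

Of the compounds shown here, two that share one core have been tested in a functional assay on NCI-H460 cells (Homo sapiens) for inhibition, read by sulforhodamine B assay, with a stated time of 48 h; a lower number here means that less compound is tolerated, a higher number that more compound is tolerated. Compound 1 `CCOC(=O)[C@H](CCC(=O)O)NC(=O)c1ccc(Sc2nc3cc(N)cc(N)c3nc2-c2ccccc2)cc1` carries a longer side chain on the sulfur. In this assay compound 1 gives < 100000 nM, which is a limit of the assay and not a number. Compound 2 `Nc1cc(N)c2nc(-c3ccccc3)c(Sc3ccc(F)cc3)nc2c1` has a 4-fluorophenyl on the sulfur instead. In this assay compound 2 gives < 100000 nM, again a limit rather than a number. Where compound 2 stands can therefore only be said loosely: it sits at the limit of < 100000 nM in this assay, at which 2 of the 2 values shown sit, so its true value is not known, and no step between measured compounds can be worked out. Compound 3 `Nc1cc(N)c2nc(-c3ccccc3)c(Sc3ccc(Cl)c(Cl)c3)nc2c1` is not yet measured. The change from compound 2 is 3,4-dichlorophenyl in place of 4-fluorophenyl on a sulfur. Among the compounds with values here, with no measured step to lean on, the expected change a step that the limit leaves unreadable from compound 2 to compound 3 is none beyond the usual scatter. Compound 3 is therefore expected to give about 20000 nM in this assay, within a wide range from 2000 nM to 100000 nM, and a limit rather than a number may again be all that is reported.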

Compound 3, concentration lethal to 50% of the cells: < 100000 nM
Compound 3: a limit, no number (the forecaster's own chance of this, stated with the estimate: 50%); the middle value does not contradict the limit.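

Within the data shown here, no step from compound 2 to compound 3 can be read, since both give only a limit of the assay and not a number: the limit of < 100000 nM in this assay, at which 3 of the 3 values shown sit. The compounds shown leave open where their true values lie in this assay, and whether 3,4-dichlorophenyl in place of 4-fluorophenyl on a sulfur changes the value at all.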